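The compounds below may be only part of what the source reports. "The series", "measured", "known", "first", "only" and "open" are said of these compounds alone.

Compound 1 `Nc1nc(NCc2cccs2)nc2sc(-c3ccco3)nc12`: 6.43 nM
Compound 2 `Nc1nc(NCc2cccs2)nc2sc(-c3cccs3)nc12`: 38 nM
Compound 3 `Nc1nc(NCc2cccnc2)nc2sc(-c3ccco3)nc12`: 18.2 nM

These three compounds were tested in an assay on CHO cells for displacement of a labelled ligand from adenosine receptor A3 (Homo sapiens), read by scintillation counting, with a stated time of 120 min; a lower number here means a stronger inhibitor, a higher number a weaker inhibitor. Among them compound 2 gives the highest number, so it is the weakest inhibitor of the three; compound 3 sits nearest to it and compound 1 furthest. Compound 2 and compound 1 differ only in the group on the aromatic carbon, thiophen-2-yl in compound 2 and furan-2-yl in compound 1, and that change gave a 5.9-fold higher number from compound 1 to compound 2 (0.77 log units; beyond the scatter).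

Compound 4 `COc1ccccc1CNc1nc(N)c2nc(-c3cccs3)sc2n1` has not been measured. It differs from compound 2 in one place: 2-methoxyphenyl in place of thiophen-2-yl on a saturated chain carbon bound to a nitrogen on an aromatic ring. Within the data shown here, the only measured step at this same place is a 2.8-fold higher number from compound 1 to compound 3 (0.45 log units; beyond the scatter), a modest weakening when the group on the saturated chain carbon is exchanged. Nothing is known here about 2-methoxyphenyl at this place, so the expectation rests on that one comparable step being modest: a step of similar size is expected, in either direction, or none beyond the scatter. Compound 4 is therefore estimated at 45 nM, within a range of 12 nM to 180 nM, which corresponds to an expected step of a 1.2-fold higher number from compound 2 to compound 4 (0.07 log units; within the scatter).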

Compound 4, inhibition constant: 275 nM
Compound 4: the middle estimate sits 6.1-fold (0.79 log units) below what was measured, outside the stated range (above it).
By their numbers in this assay, from the lowest: compound 1; then compound 3; then compound 2; then compound 4.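

In this assay, putting 2-methoxyphenyl in place of thiophen-2-yl on the saturated chain carbon gave a clear loss (a 7.2-fold higher number from compound 2 to compound 4 (0.86 log units; beyond the scatter)), so the group at this place matters when thiophen-2-yl sits on the aromatic carbon as well. The earlier exchange at this place, with furan-2-yl on the aromatic carbon, moved the same way (a 2.8-fold higher number from compound 1 to compound 3 (0.45 log units; beyond the scatter)), and in both pairs the compound carrying thiophen-2-yl at this place has the lower number. No supporting measurement bears on why the number rose.

On these data alone, it remains open whether the loss follows from the methoxy group or from the six-membered ring itself, which a plain phenyl group at this place would help to separate. As far as these compounds go, it is also open whether 2-methoxyphenyl costs as much with furan-2-yl on the aromatic carbon, and how a simple amine or a longer chain at this place would behave.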